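A few compounds are considered here, and "the series" means these few. Any claim that something is new, unique, unknown or untested is made for them only; others in the source may bear on it.

Measured in an ADME assay on MT4 cells (Homo sapiens) for cytotoxicity, read by MTT assay, with a stated time of 5 days; a higher number here means that more compound is tolerated, a lower number that less compound is tolerated:
- Compound 1 `COc1cc2nc(Nc3ccc(C#N)cc3)nc(Nc3c(C)cc(/C=C/C#N)cc3C)c2cc1OC`: 10200 nM
- Compound 2 `COc1cc2nc([S+]([O-])CC(=O)Nc3ccccc3[N+](=O)[O-])nc(Nc3c(Cl)cc(/C=C/C#N)cc3Cl)c2cc1OC`: > 199000 nM

Only compound 1 has an actual number here. For compound 2, > 199000 nM is a limit of the assay and not a number.

Compound 3 `COc1cc2nc([S+]([O-])CC(=O)Nc3cccc(C(F)(F)F)c3)nc(Nc3c(Cl)cc(/C=C/C#N)cc3Cl)c2cc1OC` departs from compound 2 in one place: 3-(trifluoromethyl)phenyl in place of 2-nitrophenyl on an amide-type nitrogen. Put simply, 3-(trifluoromethyl)phenyl takes the place of 2-nitrophenyl on an amide-type nitrogen. Among the measured compounds shown here, no measured pair shows what this swap does, and compounds 1 and 2 differ in more than one place. Compound 3 is therefore judged from its close relative, compound 2, and a small to moderate fall in this assay is expected. Compound 3 may also be reported only as a limit. The estimated change is an at least 1.9-fold lower number from compound 2 to compound 3 (0.29 log units; that floor lies within the scatter). For compound 3, the estimated value is 100000 nM, with an expected range from 25000 nM to 200000 nM.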

Compound 3, half-maximal cytotoxic concentration: 21800 nM
Estimate against measurement, compound 3: 4.6-fold (0.66 log units) above, and the stated range ends above it.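

In this assay, the group on the amide-type nitrogen proves not to be a neutral choice: 3-(trifluoromethyl)phenyl in place of 2-nitrophenyl gives an at least 9.1-fold lower number from compound 2 to compound 3 (0.96 log units; beyond the scatter). Among the compounds shown here, compound 3 also brings the first number for this series of amide-bearing compounds, 21800 nM, so tolerance at this position can now be read as a real value. For compound 2 the value is a limit and not a number, so the step is only a floor and its true size stays unknown: the limit of > 199000 nM in this assay, at which 1 of the 3 values shown sits.

The compounds shown cannot separate what the loss of the nitro group contributes from what the arrival of the trifluoromethyl group contributes. Still open, from the compounds shown here alone, is how a plain phenyl, a 3-nitrophenyl, or a phenyl carrying an amine or a carboxylic acid would behave on this nitrogen.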